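The compounds below may be only part of what the source reports. "The series", "measured", "known", "first", "only" and "open" are said of these compounds alone.

Of the compounds shown here, three sharing one core have been measured in a functional assay on NCI-H460 cells (Homo sapiens); a higher number here means that more compound is needed for the effect, a lower number that less compound is needed. Compound 1 `COc1cc(C2OC(c3ccc(N)c(C)c3)=NN2C(C)=O)cc(OC)c1OC` gives 0.059 uM, compound 2 `COc1cc(C2OC(c3ccc(N(C)C)cc3)=NN2C(C)=O)cc(OC)c1OC` gives 0.044 uM, and compound 3 `COc1cc(C2OC(c3ccc(N(C)C)cc3)=NN2C(C)=O)cc(OC)c1OC(C)=O` gives 13 uM. Compound 2 therefore sits at the low end of this small set, together with compound 1 and far from compound 3.

Compound 4 `COc1cc(C2OC(c3ccc(N(C)C)cc3)=NN2C=O)cc(OC)c1OC` departs from compound 2 at a single place: hydrogen in place of methyl on a carbonyl carbon. This is hydrogen in place of methyl on a carbonyl carbon, or acetyl to formyl when the same difference is cut one bond further out. The carbonyl carbon's other neighbours are an amide-type nitrogen in a ring.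

Two measured steps start from or reach compound 2: a 1.3-fold lower number from compound 1 to compound 2 (0.13 log units; within the scatter), and a 300-fold higher number from compound 2 to compound 3 (2.47 log units; beyond the scatter). Neither touches this carbonyl carbon, so neither gives a direct size for the new change. The second does show that a single change elsewhere on compound 2 can move the number a long way, and so the range is kept wide.

With no measurement at this place, no step beyond the scatter is expected in this assay, with a slight lean toward a higher number. The expected step is a 1.8-fold higher number from compound 2 to compound 4 (0.26 log units; within the scatter). For compound 4 the estimated value is 0.08 uM, with an expected range from 0.02 uM to 0.4 uM.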

Compound 4, concentration for half-maximal effect: 0.12 uM
Compound 4: middle estimate off by 1.5-fold (0.18 log units), on the low side, within the range that was stated.
By their numbers in this assay, from the lowest: compounds 2 and 1 (each within the scatter of the next); then compound 4; then compound 3.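

In this assay, among these compounds, the change from acetyl to formyl gives a 2.7-fold higher number from compound 2 to compound 4 (0.44 log units; beyond the scatter), the first measured step at this carbonyl carbon on the amide-type nitrogen in a ring. It shows that the methyl on this carbonyl carbon is not interchangeable with hydrogen in this assay, although the step is modest and much smaller than the one seen at the oxygen on the aromatic ring, a 300-fold higher number from compound 2 to compound 3 (2.47 log units; beyond the scatter). Compound 4 at 0.12 uM also shows that a compound with hydrogen on this carbonyl carbon can still give a sub-micromolar number, so the methyl is not essential for a low number here, and no evidence is at hand on what lies behind the step.

With only methyl and hydrogen shown on this carbonyl carbon, the compounds leave open how the number responds to a longer chain such as ethyl or propyl, to a cyclopropyl group, or to an amine in that place. They also leave open whether acetyl to formyl gives a step of similar size when the 4-amino-3-methylphenyl group of compound 1 is present instead of 4-(dimethylamino)phenyl.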